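This account rests on a few compounds, and the source may have more. Where it says the series, first, only, none or still open, it means among the compounds named here.

Measured in a functional assay on the whole organism with Mus musculus as the target, in the maximal electroshock model, with a stated time of 0.5 h; a lower number here means that less compound is needed, a higher number that more compound is needed for the effect:
- compound 1 `SC1=NC(n2nc(-c3ccccc3)nc2-c2ccccc2)=CC(c2ccc(Cl)cc2)N1`: 30 mg/kg
- compound 2 `O=[N+]([O-])c1cccc(C2C=C(n3cc(-c4ccccc4)nc3-c3ccccc3)N=C(S)N2)c1`: 30 mg/kg
- compound 3 `CN(C)c1ccc(C2C=C(n3cc(-c4ccccc4)nc3-c3ccccc3)N=C(S)N2)cc1`: 100 mg/kg

In this assay compound 1 stands level with compound 2 at the digits shown, the two together at the low end of the three numbers, while compound 3 sits a clear step higher. Going by the values given here, the only step between measured compounds that differ in one place is a 3.3-fold higher number from compound 2 to compound 3 (0.52 log units; beyond the scatter), a change of the aryl group on the saturated ring carbon, the same part of the shared core that is altered here.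

Compound 4 `SC1=NC(n2nc(-c3ccccc3)nc2-c2ccccc2)=CC(c2ccc(-c3ccccc3)cc2)N1` differs from compound 1 by phenyl in place of chloro on an aromatic carbon. Among the compounds with values here, no measured pair tests phenyl in place of chloro, so the expectation rests only on the size of the one step at this aryl group, which was modest. The expected change in this assay is no change at the digits printed from compound 1 to compound 4 (within the scatter), that is, no step beyond the scatter is expected in either direction. For compound 4 the estimated minimum effective dose is 30 mg/kg, with a range from 15 mg/kg to 100 mg/kg.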

Compound 4, minimum effective dose: 100 mg/kg
For compound 4 the middle estimate is 3.3-fold (0.52 log units) below the measured one, and the stated range covers the measured number.
By their numbers in this assay, from the lowest: compounds 1 and 2 (each within the scatter of the next); then compounds 3 and 4 (each within the scatter of the next).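

In this assay, going from 4-chlorophenyl to 4-phenylphenyl gives a 3.3-fold higher number from compound 1 to compound 4 (0.52 log units; beyond the scatter), so the aromatic carbon carrying the chloro group is not indifferent to what it holds. The earlier step replaced one whole aryl group with another on the saturated ring carbon, whereas here the six-membered aromatic ring stays and only its substituent changes, from one heavy atom to six. No measurement at hand accounts for this step.

A single pair cannot separate the loss of chloro from the entry of phenyl; hydrogen, fluoro, methoxy or an amine at this place would help to tell them apart. Going by these compounds, whether the same change gives a similar step on the core of compound 2 also remains open.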